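The source may report more compounds than this note shows. Statements on the series, on what has been measured and on what is new or still open speak of the compounds shown alone.

Compound 1 `NC(=O)C1CCN(Cc2ccc([C@H]3CC[C@]4(CC3)OOC3(O4)C4CC5CC(C4)CC3C5)cc2)CC1`: 10 mL.min-1.g-1
Compound 2 `CC(C)(O)CN1CCC(Oc2ccc([C@H]3CC[C@]4(CC3)OOC3(O4)C4CC5CC(C4)CC3C5)cc2)CC1`: 18 mL.min-1.g-1

Both numbers come from an ADME assay on microsomes from liver (Homo sapiens) for metabolic stability, read by LC-MS, tested at 1 uM (a lower number here means slower removal, a higher number faster removal of the compound), and lie within the scatter of each other, so compound 2 (18 mL.min-1.g-1) stands level with compound 1 (10 mL.min-1.g-1). From compound 2 to compound 3 `NC1CCN(S(=O)(=O)c2ccc([C@H]3CC[C@]4(CC3)OOC3(O4)C4CC5CC(C4)CC3C5)cc2)CC1`, which has not yet been measured, the change is (4-aminopiperidin-1-yl)sulfonyl in place of (1-(2-hydroxy-2-methylpropyl)piperidin-4-yl)oxy on an aromatic carbon on an aromatic carbon, para to a large group. Going by the values given here, the one measured step that bears on it (a 1.8-fold higher number from compound 1 to compound 2 (0.26 log units; within the scatter)) also replaces a group on an aromatic carbon and stayed within the scatter. Among the compounds with values here, no measured compound carries the sulfonyl group, so that step is only a weak guide. In this assay no step beyond the scatter is therefore expected, and the estimated move is a 1.4-fold lower number from compound 2 to compound 3 (0.14 log units; within the scatter) within that scatter. Compound 3 is estimated at 13 mL.min-1.g-1 with an expected range from 6 mL.min-1.g-1 to 30 mL.min-1.g-1 in this measurement.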

Compound 3, intrinsic clearance in microsomes: < 7 mL.min-1.g-1
Compound 3 gave a limit, no number (the forecaster's own chance of this, stated with the estimate: 5%); middle value at least 1.8-fold (0.26 log units) from the limit.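

In this assay, compound 3 gave a limit and not a number: the limit of < 7 mL.min-1.g-1 in this assay, at which 1 of the 3 values shown sits.

Placing (4-aminopiperidin-1-yl)sulfonyl on this aromatic carbon, para to a large group, still gives an at least 2.5-fold lower number from compound 2 to compound 3 (0.41 log units; beyond the scatter), so a change at this position can move the number beyond the scatter, which a 1.8-fold higher number from compound 1 to compound 2 (0.26 log units; within the scatter) had not shown. Against the other comparison the reading is weaker, at an at least 1.4-fold lower number from compound 1 to compound 3 (0.15 log units; that floor lies within the scatter), so only the second compound's gap to compound 3 is established as real.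

The limit leaves the true size of both steps open. Also open, as far as these compounds go, is whether the sulfonyl link or the amine on the piperidine accounts for the step, and what a carboxylic acid in place of that amine would do in this assay.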